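The compounds below may be only part of what the source reports. "The series", "measured", "known", "first", "only" and "open" are said of these compounds alone.

In a functional assay on K562 cells (Homo sapiens) for cytotoxicity, read by MTT assay, with a stated time of 3 days (on this read-out higher numbers stand for weaker inhibition and lower numbers for stronger inhibition), three compounds with a shared core have been measured. Compound 1 `CNc1nc(SCc2nc3ccccc3[nH]2)nc(-c2ccccc2)c1C#N` gives 13.2 nM, compound 2 `N#Cc1c(Nc2nccs2)nc(SCc2nc3ccccc3[nH]2)nc1-c1ccccc1` gives 14.7 nM, and compound 3 `N#Cc1c(NC(N)=S)nc(SCc2nc3ccccc3[nH]2)nc1-c1ccccc1` gives 11.9 nM. Compound 3 therefore stands level with the other two, as the gaps to it show: a 1.1-fold lower number from compound 1 to compound 3 (0.05 log units; within the scatter) and a 1.2-fold lower number from compound 2 to compound 3 (0.09 log units; within the scatter). The third measured step, a 1.1-fold higher number from compound 1 to compound 2 (0.05 log units; within the scatter), is just as small. Methyl, 1,3-thiazol-2-yl and the group without a ring have so far made no difference that stands out from the scatter.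

Compound 4 `CN1CCN(c2nc(SCc3nc4ccccc4[nH]3)nc(-c3ccccc3)c2C#N)CC1` carries a new change relative to compound 3: a group of 7 heavy atoms (5 carbon, 2 nitrogen; one six-membered non-aromatic ring with 2 hetero atoms) in place of a group of 4 heavy atoms (1 carbon, 2 nitrogen, 1 sulfur; no ring), on an aromatic carbon. The measured steps are only a loose guide here. Each swaps a group on a nitrogen on an aromatic ring, whereas this change falls on an aromatic carbon and brings in a non-aromatic ring.

With nothing pointing either way, the expectation is no step beyond the scatter, an estimated 1.2-fold higher number from compound 3 to compound 4 (0.07 log units; within the scatter). The estimate for compound 4 is 14 nM, with an expected range from 5 nM to 40 nM.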

Compound 4, half-maximal inhibitory concentration: 2.4 nM
Compound 4: the middle estimate sits 5.8-fold (0.77 log units) above what was measured; measured number outside the range, below it.
By their numbers in this assay, from the lowest: compound 4; then compounds 3, 1 and 2 (each within the scatter of the next).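

This position is not indifferent to what it carries, even though methylamino, (1,3-thiazol-2-yl)amino and the group in compound 3 could not be told apart. In this assay, 4-methylpiperazin-1-yl gives a clear gain over all three (a 5.0-fold lower number from compound 3 to compound 4 (0.70 log units; beyond the scatter)) (a 6.1-fold lower number from compound 2 to compound 4 (0.79 log units; beyond the scatter)) (a 5.5-fold lower number from compound 1 to compound 4 (0.74 log units; beyond the scatter)), which makes compound 4 the most potent of the four in this cell assay. The entering group has a six-membered non-aromatic ring and 0 hydrogen-bond donors, but nothing here shows why the number falls or which of these features matters.

Going by these compounds, it remains open whether the ring alone is enough or its methyl and second nitrogen are also needed. Piperazin-1-yl without the methyl, morpholin-4-yl, piperidin-1-yl and open-chain dimethylamino at this place would help separate these possibilities.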